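Swapping the Amine Substituent: Expected Lipophilicity of Compound 4

This account rests on a few compounds, and the source may have more. Where it says the series, first, only, none or still open, it means among the compounds named here.

Measured compounds:
compound 1 `NS(=O)(=O)Oc1ccc2c(c1)CN(C(=O)c1ccc(N(Cc3ccccc3)Cc3ccco3)cc1)CC2`: 1.93
compound 2 `CC(C)CCN(CCC(C)C)c1ccc(C(=O)N2CCc3ccc(OS(N)(=O)=O)cc3C2)cc1`: 1.93
compound 3 `CCN(Cc1ccccn1)c1ccc(C(=O)N2CCc3ccc(OS(N)(=O)=O)cc3C2)cc1`: 1.93

In a physicochemical assay for lipophilicity (a lower number here means a more polar compound, a higher number a more lipophilic compound), compound 2 gives 1.93, level with compound 1 and compound 3 within the scatter of this assay. Compound 4 `CCN(Cc1ccccc1)c1ccc(C(=O)N2CCc3ccc(OS(N)(=O)=O)cc3C2)cc1` has not yet been measured; it differs from compound 2 by benzyl(ethyl)amino in place of diisopentylamino on an aromatic carbon. For the measured compounds named here, one measured step bears on this change: no change at the digits printed from compound 2 to compound 3 (within the scatter). That swap, ethyl((pyridin-2-yl)methyl)amino in place of diisopentylamino on an aromatic carbon, left this assay unchanged, and the present swap is of the same kind. For compound 4 a step of similar size is therefore expected, no change at the digits printed from compound 2 to compound 4 (within the scatter), none beyond the scatter. With compound 2 at 1.93, compound 4 is expected to give 1.93, in a range from 1.6 to 2.3.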

Compound 4, partition coefficient: 3.08
Compound 4: middle estimate off by 1.15 log units, on the low side; the whole stated range lies below it.
By their numbers in this assay, from the lowest: compounds 1, 2 and 3 (each within the scatter of the next); then compound 4.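

In this assay, for the compounds shown here, the level reading of the earlier compounds does not hold for every group at this position: benzyl(ethyl)amino in place of diisopentylamino gives a number 1.15 log units higher from compound 2 to compound 4 (beyond the scatter). Even the close swap of phenyl in place of pyridin-2-yl gives a number 1.15 log units higher from compound 3 to compound 4 (beyond the scatter), while methyl in place of furan-2-yl gives a number 1.15 log units higher from compound 1 to compound 4 (beyond the scatter). No measurement here accounts for this jump. As far as these compounds go, it remains open whether the higher number follows the phenyl ring alone or needs the ethyl as well, and how a propyl chain in place of that ethyl, or a carboxylic acid on the phenyl ring, would read.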